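A few compounds are considered here, and "the series" means these few. Any claim that something is new, unique, unknown or untested is made for them only; others in the source may bear on it.

Compound 1 `Cc1ccc(S(=O)(=O)N2C[C@@H](CCCO[Si](C)(C)C(C)(C)C)N(C(c3ccccc3)c3ccccc3)C[C@H]2C)cc1` and compound 2 `Cc1ccc(S(=O)(=O)N2C[C@@H](CCCCO[Si](C)(C)C(C)(C)C)N(C(c3ccccc3)c3ccccc3)C[C@H]2C)cc1` share one core and differ only in the silicon-protected chain. In an in vitro assay on HEK293 cells for inhibition of Voltage-dependent N-type calcium channel subunit alpha-1B (Rattus norvegicus), read by FLIPR, with a stated time of 20 min (a lower number here means a stronger inhibitor, a higher number a weaker inhibitor), compound 1 gives 2600 nM and compound 2 gives 4700 nM. Within the data shown here, the single measured step, a 1.8-fold higher number from compound 1 to compound 2 (0.26 log units; within the scatter), leaves the two numbers within the usual scatter of each other. Compound 2 thus carries the higher of the two numbers shown, with compound 1 as its only neighbour, and the two values give no ground to rank either compound.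

Compound 3 `C[C@@H]1CN(C(c2ccccc2)c2ccccc2)[C@H](CCCCO[Si](C)(C)C(C)(C)C)CN1S(=O)(=O)c1ccc(C(F)(F)F)cc1` keeps the longer chain of compound 2 and alters the sulfonyl aryl: trifluoromethyl in place of methyl on an aromatic carbon. Among the measured compounds shown here, no measured step in the set touches that aromatic ring; the only step measured concerns the chain, and it stayed within the scatter. There is thus no comparison in this series from which a direction for the aryl change could be read. The working expectation for compound 3 in this assay is therefore no step beyond the scatter, a 1.1-fold lower number from compound 2 to compound 3 (0.05 log units; within the scatter), with a deliberately wide band to reflect the absence of any relevant precedent. Compound 3 is estimated at 4200 nM, in the range 1300 nM to 13000 nM.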

Compound 3, half-maximal inhibitory concentration: 10000 nM
Compound 3: the middle estimate sits 2.4-fold (0.38 log units) below what was measured; the range from low to high includes it.
By their numbers in this assay, from the lowest: compounds 1 and 2 (each within the scatter of the next); then compound 3.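

In this assay, among these compounds, the change from 4-methylphenyl to 4-(trifluoromethyl)phenyl gives a 2.1-fold higher number from compound 2 to compound 3 (0.33 log units; beyond the scatter) and so provides the first step that lies beyond the scatter, though only modestly. The sulfonyl aryl position therefore separates two compounds, whereas the chain change between compound 1 and compound 2 did not, and here trifluoromethyl in place of methyl on an aromatic carbon, para to a large group, goes with a weaker inhibitor on the longer chain of compound 2. Nothing at hand bears on the reason for this shift.

As far as these compounds go, this is a single aryl pair, so it remains open whether the same direction holds on the shorter chain of compound 1, and whether the shift belongs to trifluoromethyl in particular or would come with other replacements of methyl. Also open, from the compounds shown here alone, is what a chlorine, a methoxy or a nitrile would do at this aromatic carbon, and what a free hydroxyl or an amine at the chain end would do in place of the silicon-protected oxygen.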